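Amine isomer of compound 3: what to expect

A few compounds are considered here, and "the series" means these few. Any claim that something is new, unique, unknown or untested is made for them only; others in the source may bear on it.

- Compound 1 (`CC(C)=CCc1cc(C(=O)Nc2cc3ccc(OCCC4CCCCN4)c(C)c3oc2=O)ccc1O`), measured at 640 nM
- Compound 2 (`CC(C)=CCc1cc(C(=O)Nc2cc3ccc(OCCCN4CCCCC4)c(C)c3oc2=O)ccc1O`), measured at > 50000 nM
- Compound 3 (`CCN(C)CCCOc1ccc2cc(NC(=O)c3ccc(O)c(CC=C(C)C)c3)c(=O)oc2c1C`), measured at 730 nM

All three values come from a functional assay on SK-BR-3 cells (Homo sapiens) for antiproliferative activity (on this read-out lower numbers stand for stronger inhibition and higher numbers for weaker inhibition), and show two compounds on a level and one far off. Compound 3 stands with compound 1, the measured step being a 1.1-fold higher number from compound 1 to compound 3 (0.06 log units; within the scatter) and thus no real difference. Compound 2 reads > 50000 nM as a limit of the assay, not a number. Set against that limit, the other two show large steps: an at least 78-fold higher number from compound 1 to compound 2 (1.89 log units; beyond the scatter) and an at least 68-fold lower number from compound 2 to compound 3 (1.83 log units; beyond the scatter).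

Compound 4 (`CCCNCCCOc1ccc2cc(NC(=O)c3ccc(O)c(CC=C(C)C)c3)c(=O)oc2c1C`) has the same atoms as compound 3, joined differently: propylamino in place of ethyl(methyl)amino on a saturated chain carbon, three bonds along the chain from an oxygen on an aromatic ring. Among the measured compounds shown here, no measured step makes exactly this change. The nearest guide is a 1.1-fold higher number from compound 1 to compound 3 (0.06 log units; within the scatter), where piperidin-2-yl gives way to an open-chain group with no shift beyond the scatter. That points to no clear change here. Still, an at least 68-fold lower number from compound 2 to compound 3 (1.83 log units; beyond the scatter) shows that the group at this place can matter greatly, so the range stays wide. The estimate is a 1.1-fold higher number from compound 3 to compound 4 (0.04 log units; within the scatter), an expected step within the scatter. Compound 4 is expected at 800 nM, with an estimated range of 250 nM to 3000 nM.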

Compound 4, half-maximal inhibitory concentration: 990 nM
Estimate against measurement, compound 4: 1.2-fold (0.09 log units) below, and the stated range covers the measured number.
By their numbers in this assay, from the lowest: compounds 1, 3 and 4 (each within the scatter of the next). At a limit, above all of these: compound 2.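

In this assay, among the compounds shown here, the change from ethyl(methyl)amino to propylamino gives a 1.4-fold higher number from compound 3 to compound 4 (0.13 log units; within the scatter) and so offers the first direct reading of two open-chain amines with the same atoms at this place, where a group with 1 hydrogen-bond donor takes the place of one with 0 hydrogen-bond donors without a shift beyond the scatter. Compound 4 also stays level with the ring-bearing compound 1, as a 1.5-fold higher number from compound 1 to compound 4 (0.19 log units; within the scatter) shows, so piperidin-2-yl and both open-chain amines now read alike in this assay. Propylamino in place of piperidin-1-yl gives an at least 50-fold lower number from compound 2 to compound 4 (1.70 log units; beyond the scatter) and thus repeats the large gap already seen for ethyl(methyl)amino, a gap that rests on the limit for compound 2, which is a limit and not a number: the limit of > 50000 nM in this assay, at which 1 of the 4 values shown sits.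

The compounds shown leave open whether a pyrrolidin-1-yl or a diethylamino group on the same propyl chain would read with compound 3 or with compound 2. They also do not tell how a primary amine or a morpholin-4-yl group would read at this place.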